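The source may report more compounds than this note shows. Statements on the series, on what has been measured and on what is new or still open speak of the compounds shown alone.

In a functional assay on HL-60 cells (Homo sapiens), read by calcium flux (a lower number here means that less compound is needed, a higher number that more compound is needed for the effect), compound 3 `COc1cccc(Cc2cc(C3CCCCC3)nn(CC(=O)Nc3ccc(Br)cc3)c2=O)c1` gives only a limit of the assay, > 50000 nM. Compound 1 `COc1cccc(Cc2ccnn(CC(=O)Nc3ccc(Br)cc3)c2=O)c1` likewise reaches only a limit, > 50000 nM. Compound 2 `COc1cccc(Cc2cc(C(C)C)nn(CC(=O)Nc3ccc(Br)cc3)c2=O)c1` also stops at a limit, > 50000 nM. All three values sit at the same boundary, (the limit of > 50000 nM in this assay, at which 3 of the 3 values shown sit), so the steps a step that the two limits leave unreadable from compound 1 to compound 2, a step that the two limits leave unreadable from compound 1 to compound 3 and a step that the two limits leave unreadable from compound 2 to compound 3 cannot be sized. Compound 4 `COc1cccc(Cc2cc(-c3ccccc3)nn(CC(=O)Nc3ccc(Br)cc3)c2=O)c1` differs from compound 3 by phenyl in place of cyclohexyl on an aromatic carbon. Among the measured compounds shown here, no measured step with a readable size bears on this change, and nothing in the figures so far points to a gain in this assay. Compound 4 is therefore expected to remain near the same limit, with an estimated value of 50000 nM between 20000 nM and 100000 nM. The step of a number no higher from compound 3 to compound 4 (the limit leaves the size open) that this estimate implies is expected to stay within the scatter.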

Compound 4, half-maximal effective concentration: > 50000 nM
Compound 4 gave a limit, no number; the forecaster's own chance of this, stated with the estimate: 85%; the middle value lies on the limit itself.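

Compound 4 also stops at a limit, so no step between it and compound 1, compound 2 or compound 3 can be read: the limit of > 50000 nM in this assay, at which 4 of the 4 values shown sit.

The compounds shown leave open whether any group on this aromatic carbon gives a readable value in this assay.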